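This account rests on a few compounds, and the source may have more. Where it says the series, first, only, none or still open, it means among the compounds named here.

In a functional assay on KB cells (Homo sapiens) for cytotoxicity, read by MTT assay, with a stated time of 48 h (on this read-out higher numbers stand for weaker inhibition and lower numbers for stronger inhibition), compound 1 `CCn1cc(-c2nc3ccccc3[nH]2)c(=O)c2cc(F)c(N3CCNCC3)nc21` gives 2000 nM and compound 2 `CCn1cc(-c2nc3ccc(Cl)cc3[nH]2)c(=O)c2cc(F)c(N3CCNCC3)nc21` gives 10300 nM as the higher of the two numbers. Compound 3 `CCn1cc(-c2nc3ccc([N+](=O)[O-])cc3[nH]2)c(=O)c2cc(F)c(N3CCNCC3)nc21` keeps the shared core and differs from compound 2 by nitro in place of chloro on an aromatic carbon in one place, with nitro in place of chloro on an aromatic carbon. Among the measured compounds shown here, only one measured step bears on this change: a 5.2-fold higher number from compound 1 to compound 2 (0.71 log units; beyond the scatter) for chloro in place of hydrogen on an aromatic carbon, a modest step beyond the scatter. For the measured compounds named here, no measured compound carries nitro, so the data do not fix the direction of the change. The expected move is small, a 1.7-fold lower number from compound 2 to compound 3 (0.23 log units; within the scatter) and no larger than the scatter, with lower numbers slightly favoured. In this assay compound 3 is estimated at 6000 nM with a range from 1500 nM to 20000 nM as the expected span.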

Compound 3, half-maximal inhibitory concentration: 22400 nM
Compound 3: middle estimate off by 3.7-fold (0.57 log units), on the low side; measured number above the stated range.
By their numbers in this assay, from the lowest: compound 1; then compound 2; then compound 3.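

In this assay, a second group on this carbon of the six-membered aromatic ring moves the number further from that of the unsubstituted compound rather than back towards it, with a 2.2-fold higher number from compound 2 to compound 3 (0.34 log units; beyond the scatter). Measured against hydrogen the change is larger, with an 11-fold higher number from compound 1 to compound 3 (1.05 log units; beyond the scatter), so both chloro and nitro go towards weaker inhibition here, and nitro goes further. Nothing available explains this difference between the two groups.

Whether an amine or a carboxylic acid on this same carbon would also raise the number remains open, since hydrogen, chloro and nitro are the only substituents shown here. Going by these compounds, it is also open whether the same order of these three would hold on another carbon of that ring.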